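Pendant phenyl change in a benzofuranyl-carbinol series

The source may hold more compounds than are shown below. What is called first, only, known or untested is meant among the compounds shown, and "the series" means these compounds.

Three compounds have numbers in a functional assay on QG-56 cells (Homo sapiens) for antiproliferative activity; a higher number here means a weaker inhibitor, a lower number a stronger inhibitor. Compound 1 `COc1cccc(-c2cc(CN(C)C)cc3cc(C(O)(c4ccc(C#N)cc4)c4cncn4C)oc23)c1` gives 142 nM. Compound 2 `Cn1cncc1C(O)(c1ccc([N+](=O)[O-])cc1)c1cc2cc([N+](=O)[O-])cc(-c3ccccc3)c2o1` gives 547 nM. Compound 3 `Cn1cncc1C(O)(c1ccc(C#N)cc1)c1cc2cc(C#N)cc(-c3ccccc3)c2o1` gives 14.5 nM. Compound 2 stands highest of the three: compound 1 is nearest, and its lower number lies beyond the scatter; compound 3 is furthest, and its lower number lies well beyond the scatter. For the measured compounds named here, the comparison between compound 2 and compound 3 shows that the two nitro groups of compound 2 go with a much weaker inhibitor than the two nitriles of compound 3, though no single-site step connects these two structures.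

Compound 4 `Cn1cncc1C(O)(c1ccc(I)cc1)c1cc2cc([N+](=O)[O-])cc(-c3ccccc3)c2o1` differs from compound 2 in one place: iodo in place of nitro on an aromatic carbon. The change is on the pendant phenyl only; the core keeps its nitro group. Going by the values given here, no measured pair shows this exact change, so the expectation rests on compound 2 alone and the general spread of the series. A modest step downward in this assay is expected from compound 2 to compound 4, estimated as a 1.8-fold lower number from compound 2 to compound 4 (0.26 log units; within the scatter), and unlikely to reach the level of compound 3. Compound 4 is expected at 300 nM, with a range of 100 nM to 900 nM.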

Compound 4, half-maximal inhibitory concentration: > 10000 nM
Compound 4 was reported as a limit; the forecaster's own chance of this, stated with the estimate: 2%; middle value at least 33-fold (1.52 log units) away from the limit.
By their numbers in this assay, from the lowest: compound 3; then compound 1; then compound 2. At a limit, above all of these: compound 4.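

In this assay, replacing 4-nitrophenyl with 4-iodophenyl while the rest of compound 2 stays the same gives an at least 18-fold higher number from compound 2 to compound 4 (1.26 log units; beyond the scatter). Compound 4 stands only as a limit: the limit of > 10000 nM in this assay, at which 1 of the 4 values shown sits.

For the compounds shown here, this is the first single-site step in the set, and it shows that the group on this aromatic carbon, para to a large group, can by itself decide whether measurable activity remains; no earlier pair isolated this position.

With only nitro and iodo compared here on a core that keeps its nitro group, the step cannot be assigned to the loss of nitro rather than the entry of iodo. On these data alone, whether fluoro, an amine or a carboxylic acid on this carbon would stay near compound 2 or fall away like compound 4 remains open.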